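This account rests on a few compounds, and the source may have more. Where it says the series, first, only, none or still open, it means among the compounds named here.

Measured compounds:
- Compound 1 `CCCCCCCCCCCCNC(=O)[C@@H](NC(=O)/C=C/c1ccccc1)[C@@H](C)O`. In a functional assay on MCF7 cells (Homo sapiens) for cytotoxicity, read by MTT assay, with a stated time of 48 h (a higher number here means a weaker inhibitor, a lower number a stronger inhibitor), compound 1 gives > 200000 nM, which is a limit of the assay.
- Compound 2 `C/C=C/C=C/C(=O)N[C@H](C(=O)NCCCCCCCCCCCC)[C@@H](C)O`. In this assay compound 2 gives 37100 nM.
- Compound 3 `CCCCCCCCCCCCCCNC(=O)[C@@H](NC(=O)/C=C/c1ccccc1)[C@@H](C)O`. In this assay compound 3 gives 64600 nM.

The change prop-1-en-1-yl in place of phenyl on a double-bonded chain carbon bound to a double-bonded chain carbon gives an at least 5.3-fold lower number from compound 1 to compound 2 (0.73 log units; beyond the scatter); the step is only bounded because compound 1 sits at the limit of > 200000 nM in this assay, at which 1 of the 3 values shown sits. The cores of compound 1 and compound 3 differ by ethyl in place of hydrogen on a saturated chain carbon, ten or more bonds along the chain from an amide-type nitrogen, giving an at least 3.0-fold lower number from compound 1 to compound 3 (0.49 log units; beyond the scatter). Compound 2 and compound 3 lie within the scatter of each other.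

Compound 4 `C/C=C/C=C/C(=O)N[C@H](C(=O)NCCCCCCCCCCCCCC)[C@@H](C)O` is not yet measured. It differs from compound 3 by prop-1-en-1-yl in place of phenyl on a double-bonded chain carbon bound to a double-bonded chain carbon, the same change as from compound 1 to compound 2. In this assay a step of a 4.3-fold lower number from compound 3 to compound 4 (0.63 log units; beyond the scatter) is expected, resting on an at least 5.3-fold lower number from compound 1 to compound 2 (0.73 log units; beyond the scatter). Compound 4 is thus estimated at 15000 nM, between 5000 nM and 45000 nM.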

Compound 4, half-maximal inhibitory concentration: 27800 nM
Beside the measured number, compound 4's estimate is 1.9-fold (0.27 log units) below it; low and high end bracket the measured number.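

Replacing phenyl by prop-1-en-1-yl gives a 2.3-fold lower number from compound 3 to compound 4 (0.37 log units; beyond the scatter) in this assay, so the direction of the step seen on the core of compound 1 recurs on the core of compound 3. Whether its size carries over as well is not shown: the same change on two cores in this assay, an at least 5.3-fold lower number (0.73 log units; beyond the scatter) from compound 1 to compound 2 and a 2.3-fold lower number (0.37 log units; beyond the scatter) from compound 3 to compound 4; the limit leaves it open whether they differ

Placing ethyl on the saturated chain gives a 1.3-fold lower number from compound 2 to compound 4 (0.13 log units; within the scatter), so compound 2 and compound 4 show no clear separation, and it remains unsettled whether this chain change carries from one core to the other: the same change on two cores in this assay, an at least 3.0-fold lower number (0.49 log units; beyond the scatter) from compound 1 to compound 3 and a 1.3-fold lower number (0.13 log units; within the scatter) from compound 2 to compound 4; the limit leaves it open whether they differ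

Still open, as far as these compounds go, is whether the phenyl to prop-1-en-1-yl step would hold with a longer chain on the amide nitrogen. Also open, from the compounds shown here alone, is how an amine or a carboxylic acid in place of the hydroxyl would behave.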